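The source may hold more compounds than are shown below. What is called first, only, known or untested is meant among the compounds shown, and "the series" means these compounds.

Measured compounds:
compound 1 `Nc1ncnc2c1c(-c1cc(C3CC3)on1)nn2C1CCCCC1` – 14 nM
compound 2 `CC(C)(O)Cn1nc(-c2cc(C3CC3)on2)c2c(N)ncnc21` – 217 nM
compound 3 `CCCCCCCn1nc(-c2cc(C3CC3)on2)c2c(N)ncnc21` – 927 nM

In an assay on isolated protein for inhibition of proto-oncogene tyrosine-protein kinase receptor Ret variant V804M (Homo sapiens), read by radiometric assay and 33P incorporation, in the presence of a further agent that is not named here (on this read-out lower numbers stand for stronger inhibition and higher numbers for weaker inhibition), compound 3 gives the highest number of the three; the gap is a 4.3-fold higher number from compound 2 to compound 3 (0.63 log units; beyond the scatter) and a 66-fold higher number from compound 1 to compound 3 (1.82 log units; beyond the scatter). Compound 4 `Cn1nc(-c2cc(C3CC3)on2)c2c(N)ncnc21` differs from compound 3 by hydrogen in place of hexyl on a saturated chain carbon bound to an aromatic nitrogen. Both changes seen so far at this position lowered the number: a 66-fold higher number from compound 1 to compound 3 (1.82 log units; beyond the scatter) and a 4.3-fold higher number from compound 2 to compound 3 (0.63 log units; beyond the scatter), so the group on the aromatic nitrogen matters greatly, but neither step tells what removing most of the chain does. A modest to large move downward in this assay is therefore expected, a 3.1-fold lower number from compound 3 to compound 4 (0.49 log units; beyond the scatter), with wide uncertainty. Compound 4 is estimated at 300 nM, in the range 70 nM to 1300 nM.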

Compound 4, half-maximal inhibitory concentration: 182 nM
Compound 4: middle estimate off by 1.6-fold (0.22 log units), on the high side, within the range that was stated.
By their numbers in this assay, from the lowest: compound 1; then compounds 4 and 2 (each within the scatter of the next); then compound 3.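

In this assay, trimming the chain to methyl gives a 5.1-fold lower number from compound 3 to compound 4 (0.71 log units; beyond the scatter), so the long chain carries a cost that the methyl does not, while a 1.2-fold lower number from compound 2 to compound 4 (0.08 log units; within the scatter) leaves methyl and 2-hydroxy-2-methylpropyl indistinguishable. Cyclohexyl keeps its clear lead over the small methyl, with a 13-fold higher number from compound 1 to compound 4 (1.11 log units; beyond the scatter) as the step, so a small group alone does not recover the number of compound 1. No evidence at hand accounts for these differences.

Going by these compounds, it remains open whether a smaller ring such as cyclopentyl would match cyclohexyl. Nor do these compounds show how a cyclohexyl bearing an amine would read.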